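The source may hold more compounds than are shown below. What is called first, only, known or untested is meant among the compounds shown, and "the series" means these compounds.

Measured in a functional assay on MDA-MB-231 cells (Homo sapiens) for antiproliferative activity, read by sulforhodamine B assay, with a stated time of 48 h (on this read-out lower numbers stand for stronger inhibition and higher numbers for weaker inhibition), so far:
compound 1 `COc1ccc2nc(-c3ccc(N/C=C\C(=O)c4ccc(OC)c(O)c4)c(C)c3)sc2c1` gives 14000 nM
compound 2 `COc1ccc2nc(-c3ccc(N/C=C\C(=O)c4ccc(OC)c(F)c4)c(C)c3)sc2c1` gives 2000 nM
compound 3 `COc1ccc2nc(-c3ccc(N/C=C\C(=O)c4ccc(OC)c([N+](=O)[O-])c4)c(C)c3)sc2c1` gives 17600 nM

Compound 3 lies within the scatter of compound 1 (a 1.3-fold higher number from compound 1 to compound 3 (0.10 log units; within the scatter)) and well apart from compound 2 (an 8.8-fold higher number from compound 2 to compound 3 (0.94 log units; beyond the scatter)). Compound 4 `COc1ccc2nc(-c3ccc(N/C=C\C(=O)c4cc(OC)c(OC)c([N+](=O)[O-])c4)c(C)c3)sc2c1` carries methoxy in place of hydrogen on an aromatic carbon. Among the compounds with values here, no measured step makes this kind of change. The three steps only exchange one group for another at a single place, the largest being modest (an 8.8-fold higher number from compound 2 to compound 3 (0.94 log units; beyond the scatter)), so they bear on it only loosely. No step beyond the scatter is therefore expected, and no direction is favoured. The expected change is small (a 1.2-fold lower number from compound 3 to compound 4 (0.07 log units; within the scatter)) in this estimate. Compound 4 is estimated at 15000 nM in this assay, with an expected range from 5000 nM to 40000 nM for the measurement.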

Compound 4, half-maximal inhibitory concentration: 5050 nM
Estimate against measurement, compound 4: 3.0-fold (0.47 log units) above; the measured number falls inside the stated range.
By their numbers in this assay, from the lowest: compound 2; then compound 4; then compounds 1 and 3 (each within the scatter of the next).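

In this assay, methoxy in place of hydrogen, on an aromatic carbon ortho to a methoxy group and meta to a nitro group, gives a 3.5-fold lower number from compound 3 to compound 4 (0.54 log units; beyond the scatter) and is the first step shown that adds a group rather than exchanging one. Within the data shown here, this carbon, bare in the earlier compounds, can therefore shift the read-out beyond the scatter, here towards stronger inhibition. Nothing available accounts for this gain. The compounds shown leave open whether methoxy here gives a similar step when fluoro or hydroxy replaces the nitro group, and whether an amine or a longer chain at this carbon would act like methoxy.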